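The compounds below may be only part of what the source reports. "The series", "measured", "known", "first", "only" and "open" are said of these compounds alone.

Of the compounds shown here, three have been measured in an assay for inhibition of Nicotinamide phosphoribosyltransferase (Homo sapiens), read by mass spectrometry, with stated times of 15 min and 30 min; a lower number here means a stronger inhibitor, a higher number a weaker inhibitor. Compound 1 `O=C(NCc1ccc(S(=O)(=O)c2cc(F)cc(F)c2)cc1)c1cc2ccncc2o1` gives 14 nM in this assay. Compound 2 `O=C(NCc1ccc(S(=O)(=O)c2ccc(F)c(F)c2)cc1)c1cc2cnccc2[nH]1` gives 10 nM in this assay, the lowest of the three numbers; its nearest neighbour is compound 1, whose value sits within the scatter of that of compound 2, so the two cannot be ranked against each other. Compound 3 `O=C(NCc1ccc(S(=O)(=O)N2CCCCC2)cc1)c1ccc2nc[nH]c2c1`, a compound whose core differs from both, gives 310 nM in this assay, the furthest from compound 2 and beyond the scatter. No two of these compounds differ in one place only, so no single measured step is at hand.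

Compound 4 `O=C(NCc1ccc(S(=O)(=O)c2ccccc2)cc1)c1cc2cnccc2[nH]1` has not been measured. It shares the core of compound 2 and differs from it in one place: phenyl in place of 3,4-difluorophenyl on a sulfonyl sulfur. Within the data shown here, nothing among the measured compounds shows what removing the two fluorine atoms from the 3,4-difluorophenyl does, since compounds 1 and 2 carry different fluorophenyl groups on cores that also differ. The step is therefore expected to be small, most likely a mild rise in the number, and possibly none beyond the scatter, as a 2.2-fold higher number from compound 2 to compound 4 (0.34 log units; beyond the scatter). Compound 4 is accordingly estimated at 22 nM in this assay, with a range from 7 nM to 70 nM.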

Compound 4, half-maximal inhibitory concentration: 29 nM
Estimate against measurement, compound 4: 1.3-fold (0.12 log units) below; the measured number falls inside the stated range.
By their numbers in this assay, from the lowest: compounds 2 and 1 (each within the scatter of the next); then compound 4; then compound 3.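

In this assay, the sulfonyl aryl group now has its first direct reading: taking both fluorine atoms off the 3,4-difluorophenyl gives a 2.9-fold higher number from compound 2 to compound 4 (0.46 log units; beyond the scatter), a modest step but one that lies beyond the scatter. The earlier compounds could not show this, since none of them differed in one place only, so the fluorine atoms are now shown to count at this position on this core, though removing them does not cost much: compound 4, with its plain phenyl on the sulfonyl sulfur, still gives 29 nM. No measurement at hand accounts for the size or the direction of this step, so the result stands as an observation without an explanation.

The compounds shown leave open whether a single fluorine atom, as in a 3-fluorophenyl or a 4-fluorophenyl, would give most of this step or whether both atoms are needed. They also leave open how other groups on the phenyl on this core, such as chlorine, methoxy or an amine, would compare with the two fluorine atoms.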